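Replacing 4-methylphenyl with 2-ethylphenyl in compound 3

The compounds below may be only part of what the source reports. "The series", "measured", "known", "first", "only" and "open" are said of these compounds alone.

Compound 1 `Cc1oc(-c2ccc(Cl)cc2)nc1CN1CCC(C(=O)NCCCN2C[C@H](C)C[C@H](C)C2)CC1`: > 635 10^-6 cm/s (a limit)
Compound 2 `Cc1oc(-c2c(Br)cccc2Br)nc1CN1CCC(C(=O)NCCCN2C[C@H](C)C[C@H](C)C2)CC1`: < 1 10^-6 cm/s (a limit)
Compound 3 `Cc1ccc(-c2nc(CN3CCC(C(=O)NCCCN4C[C@H](C)C[C@H](C)C4)CC3)c(C)o2)cc1`: 274 10^-6 cm/s

All three compounds were tested in a physicochemical assay for permeability, using PAMPA; a lower number here means that the compound crosses the layer more slowly, a higher number that the compound crosses the layer faster. Among the compounds with values here, compound 3 gives the only actual number, 274 10^-6 cm/s. The values of compound 1 and compound 2 are limits. Compound 4 `CCc1ccccc1-c1nc(CN2CCC(C(=O)NCCCN3C[C@H](C)C[C@H](C)C3)CC2)c(C)o1` has 2-ethylphenyl in place of 4-methylphenyl on an aromatic carbon.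

The measured steps that bear on this change are swaps of the same aryl group. The step of an at least 2.3-fold lower number from compound 1 to compound 3 (0.36 log units; beyond the scatter) is at least modest. The other two are large: an at least 630-fold lower number from compound 1 to compound 2 (2.80 log units; beyond the scatter) and an at least 270-fold higher number from compound 2 to compound 3 (2.43 log units; beyond the scatter). Within the data shown here, by name, 2-ethylphenyl stands nearer than 4-methylphenyl to the 2,6-dibromophenyl of compound 2, so a lower number is expected, though three compounds make a thin basis and a drop as large as the one to compound 2 is not expected. The estimated outcome is a 3.9-fold lower number from compound 3 to compound 4 (0.59 log units; beyond the scatter). For compound 4 the expected value is 70 10^-6 cm/s, with an estimated range from 8 10^-6 cm/s to 400 10^-6 cm/s.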

Compound 4, apparent permeability: 106 10^-6 cm/s
Compound 4: middle estimate off by 1.5-fold (0.18 log units), on the low side; the range from low to high includes it.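

In this assay, putting 2-ethylphenyl at this place on the five-membered aromatic ring in place of 4-methylphenyl gives a 2.6-fold lower number from compound 3 to compound 4 (0.41 log units; beyond the scatter), a modest step. Against 2,6-dibromophenyl, 2-ethylphenyl gives an at least 100-fold higher number from compound 2 to compound 4 (2.02 log units; beyond the scatter), so the large drop seen with the dibromo group is not repeated here, and this step rests on a limit: the limit of < 1 10^-6 cm/s in this assay, at which 1 of the 4 values shown sits. Against 4-chlorophenyl, 2-ethylphenyl gives an at least 5.9-fold lower number from compound 1 to compound 4 (0.77 log units; beyond the scatter), and this step also rests on a limit: the limit of > 635 10^-6 cm/s in this assay, at which 1 of the 4 values shown sits.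

The compounds shown leave open where 2-bromophenyl or 2-methylphenyl would fall, and so whether the large drop follows the bromine atoms or the presence of two groups on the phenyl ring. They also leave open how a phenyl ring carrying an amine or a carboxylic acid would read in this assay.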